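Chloro for Fluoro on a Fused Ring: Expecting Another Limit

A few compounds are considered here, and "the series" means these few. Any claim that something is new, unique, unknown or untested is made for them only; others in the source may bear on it.

Two measured compounds share a urea that links an aryl amine to the same core. Compound 1, `COc1cccc(NC(=O)NC2CC(C)(C)Oc3ccc(Cl)cc32)c1`, carries methoxy on the aryl ring and chloro on the fused ring. In a functional assay (aorta) with Rattus norvegicus as the target (on this read-out lower numbers stand for an effect already at smaller amounts and higher numbers for an effect only at larger amounts of compound), compound 1 gives only a limit, > 10000 nM, not a number. Compound 2, `Cc1cccc(NC(=O)NC2CC(C)(C)Oc3ccc(F)cc32)c1`, carries methyl on the aryl ring and fluoro on the fused ring. In this assay compound 2 likewise gives only a limit, > 30000 nM. Compound 2 thus stands at one of the two limits shown, (the limit of > 30000 nM in this assay, at which 1 of the 2 values shown sits), while compound 1 sits at the other, (the limit of > 10000 nM in this assay, at which 1 of the 2 values shown sits). The step to compound 3, `Cc1cccc(NC(=O)NC2CC(C)(C)Oc3ccc(Cl)cc32)c1`, is chloro in place of fluoro on an aromatic carbon, on an aromatic carbon of a six-membered carbon ring within a fused system of two rings. For the measured compounds named here, no measured pair shows this change, so its size is not known from the data. Compound 1 already holds chloro at that place and reaches only the limit > 10000 nM. On that basis compound 3 is expected to remain at a limit, the step of a number no higher from compound 2 to compound 3 (the limit leaves the size open) being none beyond the scatter. The estimate for compound 3 is 30000 nM, within 10000 nM to 100000 nM.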

Compound 3, half-maximal effective concentration: > 10000 nM
Compound 3: no number, only a limit; the forecaster's own chance of this, stated with the estimate: 80%; the middle value is on the limit's open side.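

In this assay compound 3 gives > 10000 nM, which is a limit and not a number. For the compounds shown here, compound 1 and compound 2 also give only limits, so no step to compound 3 can be read, neither for chloro in place of fluoro nor for methyl in place of methoxy. The compounds shown leave open how these three compare on actual numbers.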